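From a cyano end to a longer ester chain

This account rests on a few compounds, and the source may have more. Where it says the series, first, only, none or still open, it means among the compounds named here.

In an ADME assay on L929 cells (Mus musculus) for cytotoxicity, read by resazurin assay, with a stated time of 48 h (a higher number here means that more compound is tolerated, a lower number that less compound is tolerated), compound 1 `O=c1c2cc([N+](=O)[O-])ccc2n(CCCBr)n1Cc1ccccc1` gives 25200 nM as its measured number. Compound 2 `N#CCn1c2ccc([N+](=O)[O-])cc2c(=O)n1Cc1ccccc1` gives > 256000 nM in this assay and that is a limit, not a number. Compound 2 therefore has no exact place and is known only through the limit of > 256000 nM in this assay, at which 1 of the 2 values shown sits, as the one fixed point.

Among the measured compounds shown here, the single measured step, an at least 10-fold higher number from compound 1 to compound 2 (1.00 log units; beyond the scatter), put cyano in place of 2-bromoethyl on a saturated chain carbon bound to an aromatic nitrogen. Compound 3 `CCOC(=O)CCCn1c2ccc([N+](=O)[O-])cc2c(=O)n1Cc1ccccc1` changes that same place, and 2-(ethoxycarbonyl)ethyl in place of cyano on a saturated chain carbon bound to an aromatic nitrogen describes the swap: 2-(ethoxycarbonyl)ethyl in place of cyano.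

The measured step involves a different group, so it bears on this change only loosely. Still, compound 1 at 25200 nM shows that a chain other than cyanomethyl can sit well down the scale, so a modestly lower number is expected in this assay. A second result that is only a limit remains possible. The estimated size of the move is an at least 2.1-fold lower number from compound 2 to compound 3 (0.32 log units; beyond the scatter) for this change. For compound 3 the expected value is 120000 nM, with an estimated range from 40000 nM to 256000 nM.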

Compound 3, concentration lethal to 50% of the cells: 78100 nM
Compound 3: the middle estimate sits 1.5-fold (0.19 log units) above what was measured, within the range that was stated.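

Placing the longer ester chain on a saturated chain carbon bound to an aromatic nitrogen gives an at least 3.2-fold lower number from compound 2 to compound 3 (0.51 log units; beyond the scatter) in this assay, so this position accepts a much larger group than cyano and still keeps a measurable number high on the scale. Compound 1 and compound 3 offer a cleaner view, since the chain stays and only its end changes: ethoxycarbonyl in place of bromo gives a 3.1-fold higher number from compound 1 to compound 3 (0.49 log units; beyond the scatter), which shows that the group at the chain end alone can move the result beyond the scatter. The true size of the change from the cyano compound remains open on one side, and compound 2 is held in place by a limit, not a number: the limit of > 256000 nM in this assay, at which 1 of the 3 values shown sits.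

The step from cyanomethyl to 3-(ethoxycarbonyl)propyl changes both the length of the chain and the group at its end, so these three compounds cannot show how much of that step belongs to each. A carboxylic acid or an amine at the end of the same chain would test whether the ester itself matters or whether other end groups fall in the same part of the scale.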